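The source may hold more compounds than are shown below. What is called first, only, known or untested is meant among the compounds shown, and "the series" means these compounds.

Three compounds have so far been measured in an ADME assay on microsomes from liver (Rattus norvegicus) for metabolic stability, using NADPH, with a stated time of 10 min (a lower number here means that less of the compound is left, a higher number that more of the compound is left), with these results:

- compound 1 `NCCCCN(C[C@H]1Cc2cccnc2CN1)[C@H]1CCCc2cccnc21` has 49% left
- compound 2 `NCCCCN(C[C@@H]1Cc2cccnc2CN1)[C@H]1CCCc2cccnc21` has 37% left
- compound 3 `NC/C=C\CN(C[C@H]1Cc2ncccc2CN1)[C@H]1CCCc2cccnc21` has 11% left

Compound 3 stands lowest of the three, and both of the others lie above it by more than the scatter. Compound 4 `CN(C)CCCCN(C[C@H]1Cc2ncccc2CN1)[C@H]1CCCc2cccnc21` has not yet been measured. It differs from compound 3 by 3-(dimethylamino)propyl in place of 3-aminoprop-1-en-1-yl on a saturated chain carbon bound to an amine nitrogen so that 3-(dimethylamino)propyl takes the place of 3-aminoprop-1-en-1-yl on a saturated chain carbon bound to an amine nitrogen.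

Within the data shown here, no measured step contains this exchange. Among the measured compounds shown here, the only step at hand is a number 12 percentage points lower from compound 1 to compound 2 (beyond the scatter) and it is a modest one. It rests on the fact that compounds 1 and 2 differ only in the configuration as drawn and so leaves the chain untouched, which makes it a rough yardstick of size and no guide to direction. Since compound 3 sits at 11% at the bottom of the measured numbers, a small upward step is expected in this assay with real uncertainty about its size. The estimated change is a number 9 percentage points higher from compound 3 to compound 4 (within the scatter) and it is expected to stay small. For compound 4 the expected value is 20% with an estimated range from 6% to 42% as the likely span.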

Compound 4, percent of the compound remaining: 27%
Estimate against measurement, compound 4: 7 percentage points below; the measured number falls inside the stated range.
By their numbers in this assay, from the lowest: compound 3; then compounds 4 and 2 (each within the scatter of the next); then compound 1.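

In this assay, among these compounds, the chain on the amine nitrogen now has a step of its own, which the earlier compounds could not give: a number 16 percentage points higher from compound 3 to compound 4 (beyond the scatter). The only other step shown is a change of configuration that leaves the chain untouched, so this is the first sign that the group at this place, on a saturated chain carbon bound to an amine nitrogen, moves the read-out by more than the scatter. Nothing available explains why this exchange gives this step.

The exchange alters several things at once, since the double bond goes, the end of the chain changes from a primary amine to a dimethylamine and the count of heavy atoms rises, and the compounds shown do not separate these changes. Going by these compounds, how much of the step belongs to each stays open, as does what a saturated 4-aminobutyl chain, a 4-(dimethylamino)but-2-en-1-yl chain or a longer chain ending in a dimethylamine would give on the core of compound 3.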